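The compounds below may be only part of what the source reports. "The series", "measured", "known", "first", "only" and "open" are said of these compounds alone.

In a physicochemical assay for solubility, using the shake flask method, in simulated intestinal fluid, measured as kinetic solubility, with a stated time of 2 h, at 25 degrees C, at pH 6.5 (on this read-out higher numbers stand for higher solubility and lower numbers for lower solubility), compound 1 (`Cc1noc(-c2nc(C)c3c(c2N)C(=O)N(Cc2ccc(F)cc2)C3=O)n1`) gives < 5000 nM, which is a limit and not a number. Compound 2 (`Cc1noc(-c2nc(C)c3c(c2N)C(=O)N(Cc2ccc(Cl)cc2)C3=O)n1`) gives < 5000 nM, again a limit. Compound 3 (`Cc1noc(-c2nc(C)c3c(c2N)C(=O)N(Cc2ccc(Br)cc2)C3=O)n1`) gives < 5000 nM, also a limit, so it has no number of its own and cannot be ranked against the other two. Going by the values given here, the whole series so far comes down to the limit of < 5000 nM in this assay, at which 3 of the 3 values shown sit.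

Compound 4 (`Cc1noc(-c2nc(C)c3c(c2N)C(=O)N(C(C)c2ccccc2)C3=O)n1`) carries 1-phenylethyl in place of 4-bromobenzyl on an amide-type nitrogen in a ring. The nearest measured changes swap fluoro, chloro and bromo on an aromatic carbon, and they give a step that the two limits leave unreadable from compound 1 to compound 2, a step that the two limits leave unreadable from compound 1 to compound 3 and a step that the two limits leave unreadable from compound 2 to compound 3. These steps offer no size to carry over, so no step beyond the scatter is expected in this assay, and no direction can be argued. The expected step is a step that the limit leaves unreadable from compound 3 to compound 4. For compound 4 the estimated value is 3000 nM, with an expected range from 1000 nM to 9000 nM.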

Compound 4, solubility: 10900 nM
Compound 4: middle estimate off by 3.6-fold (0.56 log units), on the low side, outside the stated range (above it).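

Compound 4 is the first compound with a number of its own in this assay, so the amide-type nitrogen in a ring is shown to be a place where a change can be read, whereas the steps among the fluoro, chloro and bromo compounds cannot be read: the limit of < 5000 nM in this assay, at which 3 of the 4 values shown sit.

Placing 1-phenylethyl on this nitrogen gives an at least 2.1-fold higher number from compound 3 to compound 4 (0.33 log units; beyond the scatter), an at least 2.1-fold higher number from compound 2 to compound 4 (0.33 log units; beyond the scatter) and an at least 2.1-fold higher number from compound 1 to compound 4 (0.33 log units; beyond the scatter). Each of these steps swaps a whole group, so the halogen and the branch of 1-phenylethyl change together, and the data do not separate them.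

From the compounds shown here alone, how plain benzyl, with neither the halogen of compound 3 nor the branch of compound 4, would stand on this nitrogen remains open. Also open, going by these compounds, is what a group carrying an amine or a carboxylic acid would do at this place.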